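A few compounds are considered here, and "the series" means these few. Any claim that something is new, unique, unknown or untested is made for them only; others in the source may bear on it.

Working notes on the series. In an ADME assay on RAW264.7 cells (Mus musculus) for cytotoxicity, read by MTT assay (a lower number here means a stronger inhibitor, a higher number a weaker inhibitor), compound 1 `CCCCCCCCCCCCOc1cccc(O)c1C(=O)/C=C/c1ccc(O)cc1` gives > 30000 nM, which is a limit of the assay and not a number. Compound 2 `CCCCCCCCCCOc1cccc(O)c1C(=O)/C=C/c1cccc(O)c1` gives > 30000 nM in this assay, again a limit and not a number. Compound 2 therefore has no numeric value, and it sits with compound 1 at one shared limit: the limit of > 30000 nM in this assay, at which 2 of the 2 values shown sit. Within the data shown here, no step between measured compounds is available to size a change.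

Compound 3 `CCCCCCCCCCOc1cccc(O)c1C(=O)/C=C/c1ccc(C)cc1` carries 4-methylphenyl in place of 3-hydroxyphenyl on a double-bonded chain carbon bound to a double-bonded chain carbon. The expectation rests on compound 2 and its limit of > 30000 nM. The expected size of a number no higher from compound 2 to compound 3 (the limit leaves the size open) is nothing beyond the scatter, in neither direction. For compound 3 the estimated value is 30000 nM, with an expected range of 15000 nM to 60000 nM.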

Compound 3, half-maximal inhibitory concentration: > 30000 nM
Compound 3 gave a limit, no number (the forecaster's own chance of this, stated with the estimate: 80%); the middle value sits exactly at the limit.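

In this assay, among these compounds, no step from compound 2 to compound 3 can be read, since both values are limits and not numbers: the limit of > 30000 nM in this assay, at which 3 of the 3 values shown sit.

The compounds shown leave open how large the change from 3-hydroxyphenyl to 4-methylphenyl is in this assay and whether any compound of this series gives a numeric value there.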